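Alpha-keto oxazole series: removing the pyridin-2-yl substituent

This account rests on a few compounds, and the source may have more. Where it says the series, first, only, none or still open, it means among the compounds named here.

Compound 1 `CCCCCC(=O)C(F)(F)F` is the simplest member; in an assay on isolated protein for inhibition of Fatty-acid amide hydrolase 1 (Homo sapiens) (on this read-out higher numbers stand for weaker inhibition and lower numbers for stronger inhibition), compound 1 gives 28900 nM. Compound 2 `CCCCCCCC/C=C\CCCCCCC(=O)c1ncc(-c2ccccn2)o1` carries an oxazole bearing a pyridin-2-yl group, and in this assay compound 2 gives 18 nM, the lowest number of the two, with compound 1 far weaker and beyond the scatter. Compound 3 `CCCCCCCC/C=C\CCCCCCC(=O)c1ncco1` differs from compound 2 in one place: hydrogen in place of pyridin-2-yl on an aromatic carbon. Among the compounds with values here, no measured pair isolates this change, so the step is expected to be toward weaker inhibition, at a 110-fold higher number from compound 2 to compound 3 (2.05 log units; beyond the scatter), clearly beyond the scatter. Compound 3 is estimated at 2000 nM, within 400 nM to 10000 nM.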

Compound 3, inhibition constant: 17 nM
Compound 3: the middle estimate sits 120-fold (2.07 log units) above what was measured, outside the stated range (below it).
By their numbers in this assay, from the lowest: compounds 3 and 2 (each within the scatter of the next); then compound 1.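

Hydrogen in place of pyridin-2-yl on the aromatic carbon next to the ring oxygen gives a 1.1-fold lower number from compound 2 to compound 3 (0.02 log units; within the scatter) in this assay. For this pair, the six heavy atoms of pyridin-2-yl are therefore not needed for a number in this range, and compound 2 and compound 3 cannot be told apart on this read-out. Nothing available explains this result.

Going by these compounds, whether a carboxylic acid, an amine or a phenyl group at this carbon would stay within the scatter of compound 3 remains open. Also open, on these data alone, is whether the same exchange would read alike on a shorter chain.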